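Swapping 3-chlorophenyl for acetyl on a shared core

This account rests on a few compounds, and the source may have more. Where it says the series, first, only, none or still open, it means among the compounds named here.

- compound 1 `CCCn1nc(-c2cccnc2)c2ccccc2c1=O` with 3160 nM measured
- compound 2 `O=c1c2ccccc2c(-c2cccnc2)nn1Cc1cccc(Cl)c1` with 4170 nM measured

In a functional assay (trachea) with Cavia porcellus as the target (a lower number here means a stronger inhibitor, a higher number a weaker inhibitor), compound 2 gives 4170 nM and so lies within the usual scatter of compound 1. Compound 3 `CC(=O)Cn1nc(-c2cccnc2)c2ccccc2c1=O` keeps the shared core and differs from compound 2 in one group. The change is acetyl in place of 3-chlorophenyl on a saturated chain carbon bound to an aromatic nitrogen and, in words, acetyl in place of 3-chlorophenyl on a saturated chain carbon bound to an aromatic nitrogen. Going by the values given here, only one measured step touches this place, and the step of a 1.3-fold higher number from compound 1 to compound 2 (0.12 log units; within the scatter) gives no sign of sensitivity there. As far as these compounds go, a single pair is thin evidence and acetyl itself is untested, so no step beyond the scatter is expected in this assay and neither direction is favoured. An estimated 1.2-fold lower number from compound 2 to compound 3 (0.08 log units; within the scatter) would be the expected outcome. The expected value for compound 3 is 3500 nM (1200 nM to 10000 nM).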

Compound 3, half-maximal inhibitory concentration: 40700 nM
Estimate against measurement, compound 3: 12-fold (1.07 log units) below; measured number above the stated range.
By their numbers in this assay, from the lowest: compounds 1 and 2 (each within the scatter of the next); then compound 3.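

The earlier pair suggested that this position tolerates change, but in this assay acetyl gives a 9.8-fold higher number from compound 2 to compound 3 (0.99 log units; beyond the scatter) and a 13-fold higher number from compound 1 to compound 3 (1.11 log units; beyond the scatter), so the group on this chain carbon can matter a great deal. Ethyl and 3-chlorophenyl, very different groups, stay within the scatter of each other, so the weaker result with acetyl does not follow simply from how large the group is. Acetyl also brings a hydrogen-bond acceptor that 3-chlorophenyl lacks, but nothing measured here shows that this explains the loss of potency.

Going by these compounds alone, with only one acetyl compound, it remains open whether the carbonyl itself or some other feature of the group matters. An amine, a carboxylic acid or a longer chain ending in a ketone at this place could help show how general the loss is.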